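Ethyl Enters a Chain Carbon: What Compound 4 Might Show

This account rests on a few compounds, and the source may have more. Where it says the series, first, only, none or still open, it means among the compounds named here.

Of the compounds shown here, three sharing one core have been measured in a functional assay (brain) for displacement of a labelled ligand, with Rattus norvegicus as the target; on this read-out lower numbers stand for stronger inhibition and higher numbers for weaker inhibition. Compound 1 `CN1CCCC[C@H]1[C@H]1COC(c2ccccc2)(c2ccccc2)O1` gives 4400 nM, compound 2 `CCCN1CCCC[C@H]1[C@H]1COC(c2ccccc2)(c2ccccc2)O1` gives 6800 nM, and compound 3 `CN[C@@H](C)[C@H]1COC(c2ccccc2)(c2ccccc2)O1` gives 703 nM, the lowest of the three. Compound 3 differs from compound 1 by 1-(methylamino)ethyl in place of 1-methylpiperidin-2-yl on a saturated ring carbon, a step of a 6.3-fold lower number from compound 1 to compound 3 (0.80 log units; beyond the scatter). Compound 2 differs from compound 1 by ethyl in place of hydrogen on a saturated chain carbon bound to an amine nitrogen in a ring, a step of a 1.5-fold higher number from compound 1 to compound 2 (0.19 log units; within the scatter). Compound 4 `CCC[C@H](NC)[C@H]1COC(c2ccccc2)(c2ccccc2)O1` is not yet measured; it differs from compound 3 by ethyl in place of hydrogen on a saturated chain carbon, two bonds along the chain from an amine nitrogen and a saturated ring carbon. This is the same kind of change as that between compound 1 and compound 2, though the place differs: there the carbon is bound to an amine nitrogen in a ring, here it is two bonds along the chain from an amine nitrogen and a saturated ring carbon. Because the earlier step was a 1.5-fold higher number from compound 1 to compound 2 (0.19 log units; within the scatter), compound 4 is expected to show a 1.4-fold higher number from compound 3 to compound 4 (0.15 log units; within the scatter) in this assay. Compound 4 is estimated at 1000 nM, plausibly between 350 nM and 3000 nM.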

Compound 4, inhibition constant: 7000 nM
Compound 4: middle estimate off by 7.0-fold (0.85 log units), on the low side; the whole stated range lies below it.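

In this assay, ethyl in place of hydrogen on this chain carbon gives a 10-fold higher number from compound 3 to compound 4 (1.00 log units; beyond the scatter), and the same change does not keep one size across the two cores: the same change on two cores in this assay, a 1.5-fold higher number (0.19 log units; within the scatter) from compound 1 to compound 2 and a 10-fold higher number (1.00 log units; beyond the scatter) from compound 3 to compound 4, 6.4-fold (0.81 log units) apart, beyond the scatter of two such steps With 1-(methylamino)butyl in place of 1-methylpiperidin-2-yl, the result is a 1.6-fold higher number from compound 1 to compound 4 (0.20 log units; within the scatter), so the advantage seen for compound 3 is not kept by compound 4. With one pair on each core and the change at different places, this shows that the earlier step did not transfer here, but it does not show why, nor how the change would behave on any other core.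

Going by these compounds, whether 1-(methylamino)propyl would give a smaller step than the butyl group remains open. So does the effect of a cyclopropyl or a hydroxyl group on the same chain carbon.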